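The source may report more compounds than this note shows. Statements on the series, on what has been measured and on what is new or still open speak of the compounds shown alone.

Measured so far in a functional assay on A549 cells (Homo sapiens) for antiproliferative activity, read by MTT assay, with a stated time of 72 h; a lower number here means a stronger inhibitor, a higher number a weaker inhibitor:
- compound 1 `COc1cc(-n2cnc3ccc(-c4cc(F)ccc4F)cc32)cc(OC)c1OC`: 7940 nM
- compound 2 `COc1cc(-n2cnc3ccc(-c4ccc([N+](=O)[O-])cc4)cc32)cc(OC)c1OC`: 8940 nM

On these two numbers, compound 2 cannot be separated from compound 1. Compound 3 `COc1cc(-n2cnc3ccc(-c4cccc(C)c4)cc32)cc(OC)c1OC` has 3-methylphenyl in place of 4-nitrophenyl on an aromatic carbon. Among the measured compounds shown here, one measured step bears on this, also an exchange of one substituted phenyl for another at this place: a 1.1-fold higher number from compound 1 to compound 2 (0.05 log units; within the scatter). It lies within the scatter, so no step beyond the scatter is expected in this assay. The expected step is a 1.2-fold lower number from compound 2 to compound 3 (0.08 log units; within the scatter). Compound 3 is estimated at 7500 nM, with an expected range of 2800 nM to 20000 nM.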

Compound 3, half-maximal inhibitory concentration: 3820 nM
The estimate for compound 3 lay 2.0-fold (0.29 log units) above the measured number, within the range that was stated.
By their numbers in this assay, from the lowest: compound 3; then compounds 1 and 2 (each within the scatter of the next).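

In this assay, this position now shows a response to the choice of substituted phenyl: 3-methylphenyl gives a lower number than 4-nitrophenyl (a 2.3-fold lower number from compound 2 to compound 3 (0.37 log units; beyond the scatter)) and than 2,5-difluorophenyl (a 2.1-fold lower number from compound 1 to compound 3 (0.32 log units; beyond the scatter)). Among the compounds shown here, both steps are modest but lie beyond the scatter, unlike the only step available before. Nothing available accounts for this difference.

Open, from the compounds shown here alone, is how 4-methylphenyl would compare with 3-methylphenyl at this place, which would test whether the location of the methyl matters. Also open, going by these compounds, is how a phenyl bearing an amine or a carboxylic acid would behave here.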